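This account rests on a few compounds, and the source may have more. Where it says the series, first, only, none or still open, it means among the compounds named here.

Compound 1 `CCCC(Oc1ccc(-n2cc(OC)cn2)cc1)c1ccc(C(=O)NCCC(=O)O)cc1` was tested in an assay on cells for displacement of a labelled ligand from Glucagon receptor (Homo sapiens), in the presence of a further agent that is not named here (a lower number here means a stronger inhibitor, a higher number a weaker inhibitor), where compound 1 gives 4400 nM. Among the three measured compounds this is the highest number, so compound 1 is the weakest inhibitor of the set. Compound 3 `CCC(Oc1ccc(-n2cc(C(F)(F)F)cn2)cc1)c1ccc(C(=O)NCCC(=O)O)cc1` gives 1400 nM in this assay, a lower number that lies beyond the scatter, and compound 2 `CCCC(Nc1cc(C)c(-n2cc(C(F)(F)F)cn2)c(C)c1)c1ccc(C(=O)NCCC(=O)O)cc1` gives 12 nM, a far lower number still. Both of these compounds differ from compound 1 in more than one place, so their values cannot be tied to any single change.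

Compound 4 `CCCC(Oc1ccc(-n2cc(Cl)cn2)cc1)c1ccc(C(=O)NCCC(=O)O)cc1` has not yet been measured. It differs from compound 1 in one place: chloro in place of methoxy on an aromatic carbon. Going by the values given here, no measured pair shows this exact exchange, so the expectation rests loosely on compound 3, which carries a different group on the same ring and gives 1400 nM. The step expected from this change is a 2.0-fold lower number from compound 1 to compound 4 (0.30 log units; within the scatter), a modest lowering of the number close to the edge of the scatter. Compound 4 is therefore expected to give 2200 nM, within a range from 700 nM to 6000 nM.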

Compound 4, inhibition constant: 1100 nM
Compound 4: middle estimate off by 2.0-fold (0.30 log units), on the high side; measured number inside the range.
By their numbers in this assay, from the lowest: compound 2; then compounds 4 and 3 (each within the scatter of the next); then compound 1.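

Going by these compounds alone, changing 4-methoxy-1H-pyrazol-1-yl to 4-chloro-1H-pyrazol-1-yl gives a 4.0-fold lower number from compound 1 to compound 4 (0.60 log units; beyond the scatter) in this assay, the first comparison in this set in which only one place differs, and it shows that this ring carbon alone can move the number beyond the scatter. The exchange replaces two heavy atoms, including one hydrogen-bond acceptor, with a single chlorine atom and no acceptor, but this one pair cannot show which of those differences matters. No measured evidence here accounts for the lower number.

Going by these compounds, it remains open how other groups on this carbon, such as methyl, nitrile or an amine, would compare with chloro and methoxy. On these data alone, it is also open whether the same exchange would give a step of similar size on the core of compound 2.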